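A Methylsulfonyl Group Enters Compound 3

The compounds below may be only part of what the source reports. "The series", "measured", "known", "first", "only" and "open" are said of these compounds alone.

In a functional assay (Homo sapiens) for inhibition (a higher number here means a weaker inhibitor, a lower number a stronger inhibitor), compound 1 (`CS(=O)(=O)c1ccc(CSc2nc(-c3ccc(F)cc3)c(-c3ccncc3)[nH]2)cc1`) gives 330 nM and compound 2 (`C[S+]([O-])c1ccc(CSc2nc(-c3ccccc3)c(-c3ccncc3)[nH]2)cc1`) gives 840 nM as the higher of the two numbers, a gap beyond the usual scatter. Compound 3 (`CS(=O)(=O)c1ccc(CSc2nc(-c3ccccc3)c(-c3ccncc3)[nH]2)cc1`) is yet to be measured. It carries methylsulfonyl in place of the group on an aromatic carbon of compound 2, para to a large group (a group of 4 heavy atoms (1 carbon, 2 oxygen, 1 sulfur; no ring) in place of a group of 3 heavy atoms (1 carbon, 1 oxygen, 1 sulfur; no ring), on an aromatic carbon). Among the compounds with values here, no measured step isolates this change. Compound 1 also carries methylsulfonyl, though it differs elsewhere too, so a small step toward a lower number is expected in this assay, near the edge of the scatter. The estimated step runs a 1.9-fold lower number from compound 2 to compound 3 (0.27 log units; within the scatter) and stays modest. Compound 3 is estimated at 450 nM with an expected range from 200 nM to 1000 nM in this measurement.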

Compound 3, half-maximal inhibitory concentration: 1700 nM
Compound 3: the middle estimate sits 3.8-fold (0.58 log units) below what was measured, and the stated range ends below it.
By their numbers in this assay, from the lowest: compound 1; then compound 2; then compound 3.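

In this assay, methylsulfonyl on an aromatic carbon para to a large group does not lower the number: the change gives a 2.0-fold higher number from compound 2 to compound 3 (0.31 log units; beyond the scatter). The lower number of compound 1 therefore does not come with methylsulfonyl alone, since hydrogen in place of fluoro on an aromatic carbon, with methylsulfonyl kept, gives a 5.2-fold higher number from compound 1 to compound 3 (0.71 log units; beyond the scatter). No measurement at hand gives a reason for either step.

Still open, from the compounds shown here alone, is whether chloro or methoxy in place of that fluoro would keep the lower number of compound 1. Also open, going by these compounds, is how a sulfonamide or an amine in place of methylsulfonyl would compare with compound 3.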